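Swapping phenyl for methyl on a stomach inhibition series

The source may report more compounds than this note shows. Statements on the series, on what has been measured and on what is new or still open speak of the compounds shown alone.

Measured so far:
compound 1 `CC(CC(=N)S)n1nc(-c2ccccc2)ccc1=O` – 15.5%
compound 2 `Cc1ccc(=O)n(CCCCC(=N)S)n1` – 29.5%
compound 3 `N=C(S)CCCCn1nc(-c2ccccc2)ccc1=O` – 33.8%

In a functional assay on the whole organism (stomach) for inhibition, with Rattus norvegicus as the target, at a dose of 100 mg/kg by the intraduodenal route (on this read-out higher numbers stand for more inhibition at the one dose given (going by the name of the read-out) and lower numbers for less inhibition), compound 3 gives 33.8% and compound 2 gives 29.5%; the step of a number 4.3 percentage points lower from compound 3 to compound 2 (within the scatter) is methyl in place of phenyl on an aromatic carbon. Compound 1 gives 15.5% in this assay, the lowest of the three, and its difference from compound 3 is not broken down here. Compound 4 `Cc1ccc(=O)n(C(C)CC(=N)S)n1` is not yet measured; it differs from compound 1 by methyl in place of phenyl on an aromatic carbon. This is the same kind of change as from compound 3 to compound 2, though the place differs: there the methyl sits meta to a group of 7 heavy atoms, here meta to a group of 6 heavy atoms. Because the earlier step of a number 4.3 percentage points lower from compound 3 to compound 2 (within the scatter) lay within the scatter, the step of a number 2.5 percentage points lower from compound 1 to compound 4 (within the scatter) is expected to be small. Compound 4 is therefore estimated at 13%, between 3% and 25%.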

Compound 4, a percentage reported as inhibition, in the whole organism at one dose (the size of the read-out at that dose, not a potency): 32.5%
The estimate for compound 4 lay 19.5 percentage points below the measured number; the measured number lies above the stated range.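

In this assay, putting methyl in place of phenyl on an aromatic carbon gives a number 17 percentage points higher from compound 1 to compound 4 (beyond the scatter). For the compounds shown here, the size of this swap's effect therefore does not carry over unchanged from one core to the other: the same change on two cores in this assay, a number 4.3 percentage points lower (within the scatter) from compound 3 to compound 2 and a number 17 percentage points higher (beyond the scatter) from compound 1 to compound 4, 21.3 percentage points apart, beyond the scatter of two such steps With only two such pairs, this shows that the outcome depends on the core, but not which feature of the core is responsible or how the swap would behave on a third core.

The compounds shown leave open what other groups on that aromatic carbon, such as an ethyl group, a methoxy group or a carboxylic acid, would do. They also leave open how a longer chain would affect the result.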